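Moving the Hydroxyl in Compound 3 to Give Compound 4

The source may hold more compounds than are shown below. What is called first, only, known or untested is meant among the compounds shown, and "the series" means these compounds.

The measured compounds:
compound 1, `Oc1ccc(-c2cc(-c3ccccc3F)cc(-c3cccc(O)c3)n2)cc1`: 14300 nM in a functional assay on HeLa cells (Homo sapiens) for inhibition; on this read-out higher numbers stand for weaker inhibition and lower numbers for stronger inhibition
compound 2, `Oc1ccc(-c2cc(-c3ccc(F)cc3)cc(-c3cccc(O)c3)n2)cc1`: 8080 nM in this assay
compound 3, `Oc1ccc(-c2cc(-c3ccccc3C(F)(F)F)cc(-c3ccccc3O)n2)cc1`: 16500 nM in this assay

Compound 3 carries the highest of the three numbers in this assay. Its gap to compound 1 lies within the scatter of the assay, while its gap to compound 2 lies just beyond it, so compound 3 and compound 1 cannot be told apart, and compound 3 sits only slightly above compound 2.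

Compound 4, `Oc1ccc(-c2cc(-c3ccccc3C(F)(F)F)cc(-c3cccc(O)c3)n2)cc1`, is obtained from compound 3 by a single change: 3-hydroxyphenyl in place of 2-hydroxyphenyl on an aromatic carbon. For the measured compounds named here, the only measured step, a 1.8-fold lower number from compound 1 to compound 2 (0.25 log units; within the scatter), concerns the fluorophenyl group and not the hydroxyphenyl group, so it does not bear directly on this change. What the data do show is that compound 1 and compound 2, which both carry the 3-hydroxyphenyl group, give numbers in the same range as compound 3. On that basis the step from compound 3 to compound 4 is expected to stay within the scatter, that is a 1.2-fold lower number from compound 3 to compound 4 (0.07 log units; within the scatter). Compound 4 is therefore estimated at 14000 nM in this assay, with a range from 6000 nM to 35000 nM.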

Compound 4, half-maximal inhibitory concentration: 17400 nM
The estimate for compound 4 lay 1.2-fold (0.09 log units) below the measured number, within the range that was stated.
By their numbers in this assay, from the lowest: compounds 2, 1, 3 and 4 (each within the scatter of the next, the first and the last beyond it).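

In this assay, moving the hydroxyl at this position, next to the ring nitrogen, gives a 1.1-fold higher number from compound 3 to compound 4 (0.02 log units; within the scatter), so with the 2-(trifluoromethyl)phenyl group present, 2-hydroxyphenyl and 3-hydroxyphenyl cannot be told apart here. With 3-hydroxyphenyl held in place, trifluoromethyl in place of fluoro gives a 1.2-fold higher number from compound 1 to compound 4 (0.09 log units; within the scatter), whereas 2-(trifluoromethyl)phenyl in place of 4-fluorophenyl gives a 2.2-fold higher number from compound 2 to compound 4 (0.33 log units; beyond the scatter), a modest step. For the compounds shown here, the only one of these new steps that goes beyond the scatter therefore concerns the group carrying the fluoro or trifluoromethyl, not the hydroxyphenyl group.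

No evidence is available to explain why the hydroxyl change leaves no readable difference in the number. On these data alone, whether the same holds with 4-fluorophenyl in the shared core remains open, as does what an amine or a carboxylic acid in place of the hydroxyl on this ring would do to the number.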